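Adding a second hydroxy group to a bromophenyl enone sulfide

The source may hold more compounds than are shown below. What is called first, only, known or untested is meant among the compounds shown, and "the series" means these compounds.

Measured so far:
compound 1, `O=C(/C(=C\c1ccc(Br)cc1)Sc1ccc(Br)cc1)c1ccc(Br)cc1`, 1000 nM;
compound 2, `O=C(/C(=C\c1ccc(Br)c(O)c1)Sc1ccc(Br)cc1)c1ccc(Br)cc1`, 1000 nM;
compound 3, `O=C(/C(=C\c1ccccc1O)Sc1ccccc1Br)c1ccc(Br)cc1`, 50000 nM.

All three were tested in a functional assay on DU-145 cells (Homo sapiens) for inhibition, read by trypan blue exclusion, with a stated time of 96 h; a lower number here means a stronger inhibitor of growth, a higher number a weaker inhibitor of growth. Compound 1 gives 1000 nM, and compound 2 gives 1000 nM, so the step of no change at the digits printed from compound 1 to compound 2 (within the scatter), the change being (hydroxy in place of hydrogen on an aromatic carbon). Compound 3 sits apart at 50000 nM in this assay; the difference between the core of compound 3 and the core of compound 1 is not broken down here.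

Compound 4, `O=C(/C(=C\c1ccc(O)cc1O)Sc1ccccc1Br)c1ccc(Br)cc1`, has not been measured. It differs from compound 3 by hydroxy in place of hydrogen on an aromatic carbon. This is the same kind of change as from compound 1 to compound 2, but the surroundings differ: there the new hydroxy sat ortho to a bromo group and meta to a large group, here it sits meta to a hydroxy group and para to a large group. Because the earlier step of no change at the digits printed from compound 1 to compound 2 (within the scatter), the step of no change at the digits printed from compound 3 to compound 4 (within the scatter) is expected to be small as well. Compound 4 is therefore estimated at 50000 nM in this assay, most likely between 15000 nM and 150000 nM.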

Compound 4, concentration for 50% growth inhibition: 50000 nM
Compound 4: the middle estimate sits on the measured number at the digits printed; the measured number falls inside the stated range.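

The added hydroxy group, which turns 2-hydroxyphenyl into 2,4-dihydroxyphenyl, gives no change at the digits printed from compound 3 to compound 4 (within the scatter). Set beside the earlier step, the same change carries over between the two cores in this assay: the same change on two cores in this assay, no change at the digits printed (within the scatter) from compound 1 to compound 2 and no change at the digits printed (within the scatter) from compound 3 to compound 4, 1.0-fold (0.00 log units) apart, within the scatter of two such steps

Within the data shown here, this rests on only two pairs, with the hydroxy group in different surroundings in each, so it does not show that the change would behave the same way elsewhere on these cores or on other cores, and it gives no reason for the lack of change.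

The compounds shown leave open whether a different group in the same place, such as an amine, a methoxy group or a carboxylic acid, would shift the growth inhibition in this assay. They also leave open whether a hydroxy group on the other aromatic rings would behave in the same way.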